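The source may hold more compounds than are shown below. What is called first, only, known or untested is meant among the compounds shown, and "the series" means these compounds.

Compound 1 `O=C1c2ccccc2S(=O)(=O)N1CCCCCN1CCN(c2ccc(Cl)cc2)CC1` is the anchor of this small set. In an assay on HEK293 cells for displacement of a labelled ligand from 5-hydroxytryptamine receptor 7 (Homo sapiens) (a higher number here means a weaker inhibitor, a lower number a stronger inhibitor), compound 1 gives 191 nM, the lowest of the three numbers recorded. Compound 2 `O=C1c2ccccc2S(=O)(=O)N1CCCCCCN1CCN(c2cccc(Cl)c2Cl)CC1` gives 487 nM in this assay, and compound 3 `O=C1c2ccccc2S(=O)(=O)N1CCCCCCN1CCN(c2ncccn2)CC1` gives 2520 nM; compound 1 and compound 2 differ in more than one place, so their values are simply set side by side. Within the data shown here, the only single change measured is the one from compound 2 to compound 3, a 5.2-fold higher number from compound 2 to compound 3 (0.71 log units; beyond the scatter), which replaces one aryl group on the ring nitrogen with another. Compound 4 `COc1ccccc1N1CCN(CCCCCN2C(=O)c3ccccc3S2(=O)=O)CC1` is made from compound 1 by 2-methoxyphenyl in place of 4-chlorophenyl on an amine nitrogen in a ring. Among the measured compounds shown here, no measured step swaps one substituted phenyl for another, so the step from compound 2 to compound 3 bears on it only loosely; it suggests the aryl group matters, but not by how much here. Compound 4 is therefore expected to stay close to compound 1, with a step of a 1.3-fold lower number from compound 1 to compound 4 (0.10 log units; within the scatter) in this assay, and an estimated value of 150 nM, within a range of 40 nM to 600 nM.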

Compound 4, inhibition constant: 125 nM
Beside the measured number, compound 4's estimate is 1.2-fold (0.08 log units) above it, within the range that was stated.
By their numbers in this assay, from the lowest: compounds 4 and 1 (each within the scatter of the next); then compound 2; then compound 3.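

In this assay, among these compounds, 2-methoxyphenyl in place of 4-chlorophenyl on an amine nitrogen in a ring gives a 1.5-fold lower number from compound 1 to compound 4 (0.18 log units; within the scatter), the first measured exchange of one substituted phenyl for another. At this position, then, the two groups cannot be told apart, even though the entering group carries a hydrogen-bond acceptor that the leaving group lacks, whereas the exchange of 2,3-dichlorophenyl for pyrimidin-2-yl gave a 5.2-fold higher number from compound 2 to compound 3 (0.71 log units; beyond the scatter) on the compounds with the other chain. No measurement given here offers an explanation for this result. 

The compounds shown leave open whether an unsubstituted phenyl or a 2-ethoxyphenyl group would also stay within the scatter of compound 1. They also leave open whether pyrimidin-2-yl on the chain of compound 1 would produce a step of similar size.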